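A few compounds are considered here, and "the series" means these few. Any claim that something is new, unique, unknown or untested is made for them only; others in the source may bear on it.

Working notes on the series. Of the compounds shown here, two have been measured so far in an assay on HEK293 cells for agonist activity at Glucose-dependent insulinotropic receptor (Homo sapiens), read by a luciferase reporter, with a stated time of 24 h; a lower number here means that less compound is needed, a higher number that more compound is needed for the effect. Compound 1 `CC(C)(C)OC(=O)N1CCC(OC(=O)c2cn(-c3nc4ccccc4s3)nn2)CC1` gives 8.17 nM in this assay. Compound 2 `CC(C)(C)OC(=O)N1CCC(OC(=O)c2cn(-c3ccc(S(C)(=O)=O)cc3F)nn2)CC1` gives 14 nM in this assay. For the measured compounds named here, of the two numbers the one for compound 2 is the higher, yet the gap between compound 2 and compound 1 lies within the scatter of repeated measurements, so the two read as equivalent and no order between them is claimed.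

Compound 3 `CC(C)(C)OC(=O)N1CCC(OC(=O)c2cn(-c3ccc(S(C)(=O)=O)cc3)nn2)CC1` has not yet been measured. It differs from compound 2 in one place: hydrogen in place of fluoro on an aromatic carbon. The shared core and the methylsulfonyl group are unchanged.

Going by the values given here, no pair of measured compounds separated by a single change is available, and compound 1 and compound 2 differ in too many places for their two values to say anything about this particular change. The expectation therefore rests only on the smallness of the change, a single fluorine leaving. The expected step is a 1.3-fold higher number from compound 2 to compound 3 (0.11 log units; within the scatter), nothing beyond the scatter. For compound 3 the estimated value in this assay is 18 nM, with a range from 6 nM to 55 nM.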

Compound 3, half-maximal effective concentration: 3.67 nM
For compound 3 the middle estimate is 4.9-fold (0.69 log units) above the measured one; measured number outside the range, below it.
By their numbers in this assay, from the lowest: compound 3; then compounds 1 and 2 (each within the scatter of the next).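

Hydrogen in place of fluoro, on the aromatic carbon ortho to a large group and meta to a methylsulfonyl group, gives in this assay a 3.8-fold lower number from compound 2 to compound 3 (0.58 log units; beyond the scatter) and so marks this position as one where a single atom changes the number beyond the scatter. For the compounds shown here, the fluoro is therefore not required for the effect at this position, and its loss lowers the amount of compound needed, which is the first single change with a readable direction. The aryl group on the aromatic nitrogen also proves to matter once the fluoro is absent: 4-(methylsulfonyl)phenyl in place of 1,3-benzothiazol-2-yl gives a 2.2-fold lower number from compound 1 to compound 3 (0.35 log units; beyond the scatter) and leaves compound 3 with the lowest number of the three.

On these data alone, whether other groups on this aromatic carbon, such as chloro, methoxy or an amine, would keep the number as low as hydrogen does remains open, as does whether the same exchange of fluoro for hydrogen would give a step of similar size on a different core. Nothing at hand accounts for the size of this step.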